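A few compounds are considered here, and "the series" means these few. Any claim that something is new, unique, unknown or untested is made for them only; others in the source may bear on it.

Measured so far in a functional assay on a cell-free system (Platelet, plasma, Homo sapiens) for inhibition (a higher number here means a weaker inhibitor, a lower number a stronger inhibitor), are two compounds.
- compound 1 `O=C(O)COC1CCN(CCN(C(=O)c2ccc(Cl)cc2)c2ccc(Cl)cc2)CC1` gives 1500 nM
- compound 2 `O=C(O)COC1CCN(CCN(C(=O)c2cccc(Cl)c2)c2ccc(Cl)cc2)CC1` gives 350 nM

Compound 2 holds the lowest number of the two. Next is compound 3 `COc1cccc(C(=O)N(CCN2CCC(OCC(=O)O)CC2)c2ccc(Cl)cc2)c1` with methoxy in place of chloro on an aromatic carbon as the change, methoxy in place of chloro on an aromatic carbon, meta to a large group. Within the data shown here, the only measured step bearing on this group is a 4.3-fold lower number from compound 1 to compound 2 (0.63 log units; beyond the scatter) and it relocated the chloro rather than replacing it. Among the measured compounds shown here, no measured step exchanges chloro for methoxy, so no step beyond the scatter is expected in this assay and no direction is firm. The estimated change is a 1.1-fold higher number from compound 2 to compound 3 (0.06 log units; within the scatter) for now. Compound 3 is expected at 400 nM with an estimated range of 130 nM to 1200 nM for now.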

Compound 3, half-maximal inhibitory concentration: 74 nM
Beside the measured number, compound 3's estimate is 5.4-fold (0.73 log units) above it; measured number outside the range, below it.
By their numbers in this assay, from the lowest: compound 3; then compound 2; then compound 1.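

In this assay, exchanging the group at this position moves the number further than the earlier relocation of chloro alone suggested: methoxy in place of chloro gives a 4.7-fold lower number from compound 2 to compound 3 (0.67 log units; beyond the scatter). Among these compounds, measured against the 4-chlorophenyl carbonyl, 3-methoxyphenyl gives a 20-fold lower number from compound 1 to compound 3 (1.31 log units; beyond the scatter), the largest step so far, so this aromatic ring is a sensitive site for substitution. No measurement shown accounts for the gain from methoxy.

From the compounds shown here alone, whether the gain extends to ethoxy or hydroxy on the same aromatic carbon remains open. Also open, going by these compounds, is whether methoxy keeps this effect at the position of the chloro in compound 1.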